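The source may hold more compounds than are shown below. What is called first, only, known or untested is meant among the compounds shown, and "the series" means these compounds.

In a functional assay on the whole organism (strain Kunming) with Mus musculus as the target, with a stated time of 0.5 h (a lower number here means that less compound is needed, a higher number that more compound is needed for the effect), compound 1 (`COc1cc(OC)c(OC)cc1/C=C/COC(=O)/C=C/c1cc(OC)c(OC)c(OC)c1OC`) gives 65.1 umol/kg and compound 2 (`COc1cc(OC)c(OC)cc1/C=C/COC(=O)/C=C/c1ccccc1C(F)(F)F`) gives 203 umol/kg. Compound 2 holds the higher of the two numbers, and the gap lies beyond the scatter. Compound 3 (`COc1cc(OC)c(OC)cc1/C=C/COC(=O)/C=C/c1ccc(Cl)cc1`) comes next, with the change (4-chlorophenyl in place of 2-(trifluoromethyl)phenyl on a double-bonded chain carbon bound to a double-bonded chain carbon). Going by the values given here, no measured step differs in one place only, so the expectation rests on these two values alone. A small drop, within the scatter, is expected, the estimated change being a 1.7-fold lower number from compound 2 to compound 3 (0.23 log units; within the scatter). For compound 3 the expected value is 120 umol/kg, with an estimated range of 50 umol/kg to 280 umol/kg.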

Compound 3, dose for half-maximal effect: 137 umol/kg
The estimate for compound 3 lay 1.1-fold (0.06 log units) below the measured number; measured number inside the range.
By their numbers in this assay, from the lowest: compound 1; then compounds 3 and 2 (each within the scatter of the next).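

In this assay, 4-chlorophenyl in place of 2-(trifluoromethyl)phenyl on a double-bonded chain carbon bound to a double-bonded chain carbon gives a 1.5-fold lower number from compound 2 to compound 3 (0.17 log units; within the scatter), so this position accepts this exchange without a change beyond the scatter. Going by these compounds alone, the single step cannot separate the change of halogen-bearing group from the change in where it sits on the phenyl ring. Nothing available bears on the cause of this result. Still open, going by these compounds, is whether an amine or a carboxylic acid on the phenyl ring would keep the number in this range. Changes to the rest of the shared core also remain open.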